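The source may report more compounds than this note shows. Statements on the series, on what has been measured and on what is new or still open speak of the compounds shown alone.

Compound 1 `Nc1cc(N)c2nc(-c3ccccc3)c(Oc3ccc(Cl)c(Cl)c3)nc2c1` was examined in a functional assay on NCI-H23 cells (Homo sapiens) for inhibition, read by sulforhodamine B assay, with a stated time of 48 h; on this read-out lower numbers stand for higher toxicity in this test and higher numbers for lower toxicity in this test. For compound 1 the reading in this assay is a limit of the method rather than a number, namely < 100000 nM. Compound 2 `COc1ccc(CNc2nc3cc(N)cc(N)c3nc2-c2ccccc2)cc1OC` shares the same core; in this assay compound 2 gives 91200 nM. Taken together the two results sit at the weak end of the scale, one of them at the limit of < 100000 nM in this assay, at which 1 of the 2 values shown sits, so the series as measured so far shows little toxicity toward these cells.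

Compound 3 `Nc1cc(N)c2nc(-c3ccccc3)c(Oc3ccc(F)cc3)nc2c1` has not yet been measured in this assay. It differs from compound 1 in one place: 4-fluorophenyl in place of 3,4-dichlorophenyl on an oxygen on an aromatic ring. For the measured compounds named here, since compound 1 offers only a limit and no step between measured compounds is available, the size of the change from compound 1 to compound 3 cannot be read from the data; the expectation is for no movement beyond the usual scatter, with any shift, if present, toward lower toxicity. Compound 3 is therefore estimated at 85000 nM in this assay, with a plausible range from 25000 nM to 250000 nM. The expected step that the limit leaves unreadable from compound 1 to compound 3 is accordingly small.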

Compound 3, concentration lethal to 50% of the cells: 77600 nM
Compound 3: the middle estimate sits 1.1-fold (0.04 log units) above what was measured; measured number inside the range.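

No new step can be read from compound 1 to compound 3, because the reading for compound 1 is a limit of the method and not a number: the limit of < 100000 nM in this assay, at which 1 of the 3 values shown sits.

The compounds shown leave open whether 3,4-dichlorophenyl and 4-fluorophenyl on that oxygen differ at all in this assay, and whether any compound on the shared core reaches higher toxicity.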